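Trimming the Ethylamino Group: Expectation for Compound 3

This account rests on a few compounds, and the source may have more. Where it says the series, first, only, none or still open, it means among the compounds named here.

For the measured compounds named here, compound 2 `CCNc1nc(N)c2nc(O)n(Cc3ccccc3)c2n1` gives 1 uM in a functional assay (spleen, spleen) for activation, with Mus musculus as the target (a lower number here means that less compound is needed, a higher number that more compound is needed for the effect), the highest of the two numbers measured so far; its nearest neighbour, compound 1 `CCCCSc1nc(N)c2nc(O)n(Cc3ccccc3)c2n1`, gives 0.01 uM. Going by the values given here, the single measured step, a 100-fold higher number from compound 1 to compound 2 (2.00 log units; beyond the scatter), is large. Compound 3 `Nc1nc(N)c2nc(O)n(Cc3ccccc3)c2n1` differs from compound 2 by hydrogen in place of ethyl on a nitrogen on an aromatic ring. Among the compounds with values here, no measured step removes ethyl from this nitrogen, so the expectation rests only on that one step. Because of a 100-fold higher number from compound 1 to compound 2 (2.00 log units; beyond the scatter), a further but smaller rise is expected, a 3.0-fold higher number from compound 2 to compound 3 (0.48 log units; beyond the scatter). Compound 3 is therefore estimated at 3 uM, with a range from 0.5 uM to 20 uM.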

Compound 3, minimum effective concentration: 10 uM
For compound 3 the middle estimate is 3.3-fold (0.52 log units) below the measured one, and the stated range covers the measured number.
By their numbers in this assay, from the lowest: compound 1; then compound 2; then compound 3.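

In this assay, taking the ethyl off this nitrogen gives a 10-fold higher number from compound 2 to compound 3 (1.00 log units; beyond the scatter), so the step seen on replacing butylsulfanyl continues rather than levels off once the chain is gone. Amino in place of butylsulfanyl on this aromatic carbon gives a 1000-fold higher number from compound 1 to compound 3 (3.00 log units; beyond the scatter), which places the three groups in the order butylsulfanyl, ethylamino, amino. Where a butylamino group would fall remains open, and with it whether the chain length or the sulfur carries the larger share of the change. No measured evidence here bears on what lies behind these steps.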